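Replacing the acetyl group of compound 1

The compounds below may be only part of what the source reports. "The series", "measured", "known", "first", "only" and "open" are said of these compounds alone.

Measured in an ADME assay on MDBK cells (Bos taurus) for cytotoxicity, read by MTT assay, with a stated time of 96 h; a higher number here means that more compound is tolerated, a lower number that less compound is tolerated:
- compound 1 `CC(=O)c1ccc2c(c1)nc(-c1ccoc1)n2C1CCCCC1`: > 100000 nM
- compound 2 `CC(=O)c1ccc2c(c1)nc(-c1ccccn1)n2C1CCCCC1`: > 100000 nM
- compound 3 `CC(=O)c1ccc2[nH]c(-c3ccoc3)nc2c1`: >= 100000 nM

Compound 1 stands only at a limit, > 100000 nM, and not at a number. The values of compound 2 and compound 3 are limits too. The next compound is compound 4 `C/C(=N\NC(N)=O)c1ccc2c(c1)nc(-c1ccoc1)n2C1CCCCC1`, and the change is a group of 7 heavy atoms (3 carbon, 3 nitrogen, 1 oxygen; no ring) in place of a group of 3 heavy atoms (2 carbon, 1 oxygen; no ring), on an aromatic carbon. Going by the values given here, two measured steps bear on it only loosely: a step that the two limits leave unreadable from compound 1 to compound 2 and a step that the two limits leave unreadable from compound 1 to compound 3. Neither touches the acetyl, and neither has a readable size. In this assay, no shift beyond the scatter is therefore expected, and the estimated step is an at least 1.1-fold lower number from compound 1 to compound 4 (0.07 log units; that floor lies within the scatter). Compound 4 is estimated at 85000 nM, with an expected range of 30000 nM to 100000 nM.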

Compound 4, half-maximal cytotoxic concentration: > 100000 nM
Compound 4: a limit, no number (the forecaster's own chance of this, stated with the estimate: 60%); middle value at least 1.1-fold (0.07 log units) from the limit.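

In this assay compound 4 stands at a limit, > 100000 nM, not a number, so the step from compound 1 to it cannot be read. The compounds shown leave open where the actual values of compound 1 and compound 4 lie.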